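A Nitrile Group Replaces the Hydroxy-Methoxy Ring

The source may report more compounds than this note shows. Statements on the series, on what has been measured and on what is new or still open speak of the compounds shown alone.

In a functional assay on PC-3 cells (Homo sapiens) for cytotoxicity, read by sulforhodamine B assay, with a stated time of 48 h (on this read-out lower numbers stand for stronger inhibition and higher numbers for weaker inhibition), compound 1 `COc1ccc(C2=NO[C@]3(C2)C(=O)O[C@@H]2[C@H]3CC[C@H](C)[C@]3(O)C=CC(=O)[C@@]23C)cc1` gives 35000 nM and compound 2 `COc1cc(C2=NO[C@]3(C2)C(=O)O[C@@H]2[C@H]3CC[C@H](C)[C@]3(O)C=CC(=O)[C@@]23C)ccc1O` gives 16000 nM as the lower of the two numbers. Compound 3 `C[C@H]1CC[C@@H]2[C@@H](OC(=O)[C@]23CC(c2ccc(C#N)cc2)=NO3)[C@]2(C)C(=O)C=C[C@@]12O` has not been measured yet. It keeps the shared core but carries 4-cyanophenyl in place of 4-hydroxy-3-methoxyphenyl on a carbon with a double bond to nitrogen. For the measured compounds named here, only one measured step bears on this change. It is a 2.2-fold lower number from compound 1 to compound 2 (0.34 log units; beyond the scatter) as 4-hydroxy-3-methoxyphenyl replaced 4-methoxyphenyl at that same carbon. Going by these compounds, compound 3 gives up the group that compound 2 carries, but 4-cyanophenyl itself is untested, so the evidence is thin. A modest step of similar size toward a higher number in this assay is therefore expected, with a 2.2-fold higher number from compound 2 to compound 3 (0.34 log units; beyond the scatter) as the estimate. The expected value for compound 3 is 35000 nM with an estimated range (14000 nM to 80000 nM).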

Compound 3, half-maximal inhibitory concentration: 32000 nM
Estimate against measurement, compound 3: 1.1-fold (0.04 log units) above; low and high end bracket the measured number.
By their numbers in this assay, from the lowest: compounds 2, 3 and 1 (each within the scatter of the next, the first and the last beyond it).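

In this assay, swapping the ring on this carbon gives a 2.0-fold higher number from compound 2 to compound 3 (0.30 log units; within the scatter), and putting cyano in place of methoxy on an aromatic carbon gives a 1.1-fold lower number from compound 1 to compound 3 (0.04 log units; within the scatter). For the compounds shown here, the earlier compounds showed only one step at this position, a 2.2-fold lower number from compound 1 to compound 2 (0.34 log units; beyond the scatter), so compound 3 adds a ring with a nitrile, no hydrogen-bond donor and a different atom makeup, and neither of its steps lies beyond the scatter. No measured evidence explains how these rings compare.

The compounds shown leave open whether an amine or a carboxylic acid in place of the nitrile on this ring would move the number beyond the scatter. They also leave open whether a methyl group in place of the whole ring would read differently.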